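The source may hold more compounds than are shown below. What is called first, only, known or untested is meant among the compounds shown, and "the series" means these compounds.

Among the compounds with values here, compound 1 (`C/C=C/C(=O)N(Cc1ccc(OC)c(N)c1)c1cc(OC)c(OC)c(OC)c1`) gives 310 nM in a functional assay on KYSE-450 cells (Homo sapiens) for inhibition, read by MTT assay, with a stated time of 48 h (on this read-out lower numbers stand for stronger inhibition and higher numbers for weaker inhibition), the lower of the two numbers measured so far. Compound 2 (`COc1ccc(N(Cc2cc(OC)c(OC)c(OC)c2)C(=O)CN=[N+]=[N-])cc1O`) gives 26100 nM, a gap beyond the scatter of repeated measurements. Compound 3 (`C/C=C/C(=O)N(Cc1ccc(OC)cc1)c1cc(OC)c(OC)c(OC)c1`) has not yet been measured in this assay. It is compound 1 with a single change: hydrogen in place of amino on an aromatic carbon. In plain terms, hydrogen stands in place of amino on an aromatic carbon, so 3-amino-4-methoxyphenyl becomes 4-methoxyphenyl. Within the data shown here, no measured pair of compounds shows this change on its own, so its size can only be judged, and the uncertainty is wide. A rise in the number beyond the scatter, meaning weaker inhibition, is expected, and the estimated change is a 9.7-fold higher number from compound 1 to compound 3 (0.99 log units; beyond the scatter). Compound 3 is estimated at 3000 nM, with an expected range from 600 nM to 15000 nM.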

Compound 3, half-maximal inhibitory concentration: 420 nM
The estimate for compound 3 lay 7.1-fold (0.85 log units) above the measured number; the measured number lies below the stated range.
By their numbers in this assay, from the lowest: compounds 1 and 3 (each within the scatter of the next); then compound 2.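

Putting hydrogen in place of amino on the aromatic carbon gives a 1.4-fold higher number from compound 1 to compound 3 (0.13 log units; within the scatter) in this assay. At this place, ortho to a methoxy group, the amino group is therefore not needed for a number in this range: 4-methoxyphenyl and 3-amino-4-methoxyphenyl read alike within the scatter. Nothing available explains why the two compounds read alike.

The compounds shown compare only hydrogen and amino at this place, so they leave open how a hydroxyl group, a fluorine atom or a dimethylamino group would read there. Compound 2 differs from compound 1 and compound 3 in more than one place, so it cannot show whether the same result would hold with a different group on the amide.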